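Naphthalen-2-yl replacements on an oxygen on a saturated carbon

The compounds below may be only part of what the source reports. "The series", "measured", "known", "first", "only" and "open" are said of these compounds alone.

Measured so far in a functional assay with Homo sapiens as the target; a lower number here means a stronger inhibitor, a higher number a weaker inhibitor:
- compound 1 `CC(C)[C@H](NC(=O)COc1cccc2ccccc12)C(=O)N[C@@H](CC(=O)O)C(=O)COc1ccc2ccccc2c1`: 15900 nM
- compound 2 `CC(C)[C@H](NC(=O)COc1cccc2ccccc12)C(=O)N[C@@H](CC(=O)O)C(=O)COc1cccc(C(F)(F)F)c1`: 16600 nM
- compound 3 `CC(C)[C@H](NC(=O)COc1cccc2ccccc12)C(=O)N[C@@H](CC(=O)O)C(=O)COc1ccc(C#N)cc1`: 26700 nM

Compound 1 carries the lowest number of the three in this assay, but its separation from the others is small: a 1.0-fold higher number from compound 1 to compound 2 (0.02 log units; within the scatter) and a 1.7-fold higher number from compound 1 to compound 3 (0.23 log units; within the scatter) both fall within the usual scatter, as does a 1.6-fold higher number from compound 2 to compound 3 (0.21 log units; within the scatter). On the numbers shown, the three compounds are indistinguishable.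

Compound 4 `CC(C)[C@H](NC(=O)COc1cccc2ccccc12)C(=O)N[C@@H](CC(=O)O)C(=O)COc1cc(F)ccc1F` keeps the shared core of compound 1 and differs only at the same point already varied in compounds 2 and 3: 2,5-difluorophenyl in place of naphthalen-2-yl on an oxygen on a saturated carbon.

The two steps that bear on this change are the ones from compound 1 to compound 2 and from compound 1 to compound 3, in which a substituted phenyl replaced naphthalen-2-yl at this oxygen; neither moved the number beyond the scatter. A third single-ring replacement is therefore expected to behave alike, with no step beyond the scatter in this assay, and the step of a 1.3-fold higher number from compound 1 to compound 4 (0.10 log units; within the scatter) is the estimated outcome. Compound 4 is accordingly expected to give 20000 nM, within a range of 9000 nM to 45000 nM.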

Compound 4, half-maximal inhibitory concentration: 19700 nM
Compound 4: middle estimate off by 1.0-fold (0.01 log units), on the high side; the measured number falls inside the stated range.
By their numbers in this assay, from the lowest: compounds 1, 2, 4 and 3 (each within the scatter of the next).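

In this assay the 2,5-difluorophenyl group brings a single ring with two fluorine atoms into the set, and the step stays small: a 1.2-fold higher number from compound 1 to compound 4 (0.09 log units; within the scatter). The comparison with the other two single-ring groups gives the same picture, a 1.2-fold higher number from compound 2 to compound 4 (0.07 log units; within the scatter) and a 1.4-fold lower number from compound 3 to compound 4 (0.13 log units; within the scatter), so fluorine on the ring reads no differently from trifluoromethyl or nitrile, and compounds 1, 2, 3 and 4 all remain within the scatter of one another at this oxygen. No group among these four separates from the rest at this point, and no measurement at hand accounts for this flat response.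

On these data alone, whether any group on this oxygen can move the number beyond the scatter stays open; a phenyl ring carrying an amine or a carboxylic acid, or a longer chain in place of the ring, would test that. The compounds shown also hold the rest of the shared core fixed, so whether the same flat response would survive a change elsewhere in that core is unknown.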